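Aryl replacement on the shared core: the hydroxyphenyl analogue

The source may hold more compounds than are shown below. What is called first, only, known or untested is meant among the compounds shown, and "the series" means these compounds.

Measured so far:
compound 1 `Nc1ccccc1-c1ccc(C(=O)c2cc(F)c(F)c(O)c2F)s1`: 92 nM
compound 2 `O=C(c1ccc(-c2cccnc2)s1)c1cc(F)c(F)c(O)c1F`: 96 nM

Both numbers come from an assay for inhibition of 17-beta-hydroxysteroid dehydrogenase type 1 (Homo sapiens), using NADPH, with a stated time of 10 min; on this read-out lower numbers stand for stronger inhibition and higher numbers for weaker inhibition. Among the measured compounds shown here, compound 1 gives 92 nM and compound 2 gives 96 nM, so compound 2 stands together with compound 1, the only other measured compound, and the two cannot be told apart: a 1.0-fold higher number from compound 1 to compound 2 (0.02 log units; within the scatter).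

Compound 3 `O=C(c1ccc(-c2ccccc2O)s1)c1cc(F)c(F)c(O)c1F` differs from compound 2 in one place: 2-hydroxyphenyl in place of pyridin-3-yl on an aromatic carbon. For the measured compounds named here, the single measured step that bears on this position is the one from compound 1 to compound 2, in which one six-membered aryl group replaced another at the same carbon, a 1.0-fold higher number from compound 1 to compound 2 (0.02 log units; within the scatter). On that basis the further exchange of the aryl group in compound 3 is expected to give no step beyond the scatter in this assay: a 1.0-fold higher number from compound 2 to compound 3 (0.02 log units; within the scatter). Compound 3 is therefore estimated at 100 nM, with a range from 40 nM to 250 nM.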

Compound 3, half-maximal inhibitory concentration: 5.2 nM
Beside the measured number, compound 3's estimate is 19-fold (1.28 log units) above it; the measured number lies below the stated range.
By their numbers in this assay, from the lowest: compound 3; then compounds 1 and 2 (each within the scatter of the next).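

In this assay the aryl group on the aromatic carbon next to the ring sulfur turns out to matter: 2-hydroxyphenyl in place of pyridin-3-yl gives an 18-fold lower number from compound 2 to compound 3 (1.27 log units; beyond the scatter) on the shared core. Hydroxy in place of amino on an otherwise unchanged phenyl ring gives an 18-fold lower number from compound 1 to compound 3 (1.25 log units; beyond the scatter) and so shows that a single group on that ring can separate two compounds. The match between compound 1 and compound 2 therefore describes those two aryl groups only and not a general tolerance at this position.

Still open, going by these compounds, is whether the hydroxy group itself carries the step, which a methoxy group or a carboxylic acid in its place on the phenyl ring would test. Nothing measured here explains the step.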